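Methyl on the amide nitrogen of compound 3

The compounds below may be only part of what the source reports. "The series", "measured", "known", "first", "only" and "open" are said of these compounds alone.

Values in an in vitro ADME assay on microsomes from liver (Canis lupus familiaris) for metabolic stability; on this read-out lower numbers stand for slow clearance and higher numbers for fast clearance:
- compound 1 `CC[C@H](C)[C@@H]1C(=O)N[C@H](C2Cc3ccccc3C2)C(=O)N1[C@@H](C(=O)N(C)C)c1ccc(C)nc1C`: 1 mL.min-1.g-1
- compound 2 `CC[C@H](C)[C@@H]1C(=O)N[C@H](C2Cc3ccccc3C2)C(=O)N1[C@@H](C(=O)N(C)C)c1cnc(C)cc1C`: 1 mL.min-1.g-1
- compound 3 `CC[C@H](C)[C@@H]1C(=O)N[C@H](C2Cc3ccccc3C2)C(=O)N1[C@@H](C(=O)NC)c1cc(C)cnc1C`: 3 mL.min-1.g-1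

Compound 3 stands highest of the three in this assay, beyond the scatter from both others. Compound 4 `CC[C@H](C)[C@@H]1C(=O)N[C@H](C2Cc3ccccc3C2)C(=O)N1[C@@H](C(=O)N(C)C)c1cc(C)cnc1C` differs from it by methyl in place of hydrogen on an amide-type nitrogen, so methylcarbamoyl becomes dimethylcarbamoyl. Among the measured compounds shown here, no measured step shows this change directly. For the measured compounds named here, the nearest evidence comes from the two dimethylcarbamoyl compounds, where the one measured step reads no change at the digits printed from compound 1 to compound 2 (within the scatter), within the scatter. A fall beyond the scatter is therefore expected, toward the level of compound 1 at 1 mL.min-1.g-1. The expected step is a 2.3-fold lower number from compound 3 to compound 4 (0.36 log units; beyond the scatter). Compound 4 is estimated at 1.3 mL.min-1.g-1, with an expected range of 0.6 mL.min-1.g-1 to 3 mL.min-1.g-1.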

Compound 4, intrinsic clearance in microsomes: 2 mL.min-1.g-1
Estimate against measurement, compound 4: 1.5-fold (0.19 log units) below, and the stated range covers the measured number.
By their numbers in this assay, from the lowest: compounds 1, 2, 4 and 3 (each within the scatter of the next, the first and the last beyond it).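

In this assay methyl in place of hydrogen on the amide-type nitrogen gives a 1.5-fold lower number from compound 3 to compound 4 (0.18 log units; within the scatter) and stays within the scatter, so this change is now read directly. With dimethylcarbamoyl kept, 2,5-dimethylpyridin-3-yl in place of 4,6-dimethylpyridin-3-yl gives a 2.0-fold higher number from compound 2 to compound 4 (0.30 log units; within the scatter) and in place of 2,6-dimethylpyridin-3-yl gives a 2.0-fold higher number from compound 1 to compound 4 (0.30 log units; within the scatter) and neither step leaves the scatter. No supporting measurement bears on these numbers.

Methylcarbamoyl appears here only with 2,5-dimethylpyridin-3-yl, so its step on the other dimethylpyridin-3-yl groups stays open. As far as these compounds go, how a carboxylic acid or a diethylcarbamoyl group would read at this position also stays open.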